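The source may report more compounds than this note shows. Statements on the series, on what has been measured and on what is new or still open speak of the compounds shown alone.

Measured so far:
compound 1 `CCn1c(CNc2ccccc2)nnc1SCC(=O)Nc1ccccc1` gives > 1000 nM in an assay on isolated protein for inhibition of long-chain fatty acid transport protein 1 (Homo sapiens); on this read-out lower numbers stand for stronger inhibition and higher numbers for weaker inhibition.
compound 2 `CCn1c(CNc2ccccc2)nnc1SCC(=O)Nc1ccc(C(=O)NC)cc1` gives > 1000 nM in this assay.

As far as these compounds go, both values are limits of the assay, not numbers; compound 2 sits at the limit of > 1000 nM in this assay, at which 2 of the 2 values shown sit, so where it stands within the inactive range is unknown. Within the data shown here, the one measured step, a step that the two limits leave unreadable from compound 1 to compound 2, is unreadable and gives no size or direction.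

Compound 3 `CCOC(=O)c1ccc(NC(=O)CSc2nnc(CNc3ccccc3)n2CC)cc1` differs from compound 2 by ethoxy in place of methylamino on a carbonyl carbon. No readable step bears on this change. Compound 3 is therefore expected again at or near the limit, estimated at 3000 nM with a range from 800 nM to 20000 nM. The expected step that the limit leaves unreadable from compound 2 to compound 3 carries no readable direction.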

Compound 3, half-maximal inhibitory concentration: 330 nM
The estimate for compound 3 lay 9.1-fold (0.96 log units) above the measured number; the measured number lies below the stated range.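

Ethoxy in place of methylamino on the carbonyl carbon gives the first readable step of the series in this assay, an at least 3.0-fold lower number from compound 2 to compound 3 (0.48 log units; beyond the scatter), and ethoxycarbonyl in place of hydrogen on an aromatic carbon gives an at least 3.0-fold lower number from compound 1 to compound 3 (0.48 log units; beyond the scatter). What sits on this carbonyl carbon therefore matters, as the methylcarbamoyl of compound 2 gives no readable gain over hydrogen while the ethoxycarbonyl of compound 3 does. Both sizes are only minimum sizes, and the step from compound 1 to compound 2 cannot be read, with the two compounds resting on a limit: the limit of > 1000 nM in this assay, at which 2 of the 3 values shown sit.

The compounds shown leave open whether a carboxylic acid, a methyl ester or a longer ester chain on this carbonyl carbon would lower the number further. They also leave open how far compound 1 and compound 2 truly lie from compound 3.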